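The compounds below may be only part of what the source reports. "The series", "measured", "known", "first", "only" and "open" are said of these compounds alone.

Measured so far in a functional assay on DU-145 cells (Homo sapiens) for inhibition, read by trypan blue exclusion, with a stated time of 72 h; a higher number here means a weaker inhibitor, a lower number a stronger inhibitor:
compound 1 `Cn1c(=O)c(S(=O)(=O)c2ccc([N+](=O)[O-])cc2F)cc2cnc(Nc3ccc4[nH]ccc4c3)nc21`: 400 nM
compound 2 `Cn1c(=O)c(C(=O)Nc2ccc(F)cc2)cc2cnc(Nc3ccc4[nH]ccc4c3)nc21`: 5000 nM
compound 3 `COc1ccc(S(=O)(=O)c2cc3cnc(Nc4ccc5[nH]ccc5c4)nc3n(C)c2=O)cc1`: 500 nM

Compound 3 holds the second highest of the three numbers. Its nearest neighbour is compound 1, with a 1.3-fold higher number from compound 1 to compound 3 (0.10 log units; within the scatter), a step that swaps one aryl group for another on the sulfonyl sulfur. Within the data shown here, its furthest neighbour is compound 2, with a 10-fold lower number from compound 2 to compound 3 (1.00 log units; beyond the scatter), the only sizeable step in the set, and it separates a carbamoyl from a sulfonyl at the aromatic carbon.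

Compound 4 `Cn1c(=O)c(S(=O)(=O)Nc2ccc(F)cc2)cc2cnc(Nc3ccc4[nH]ccc4c3)nc21` is not yet measured. The change from compound 3 is (4-fluorophenyl)amino in place of 4-methoxyphenyl on a sulfonyl sulfur. Neither measured step covers this exactly: the aryl swap on the sulfonyl was flat, while the carbamoyl of compound 2, which also carries an aryl-amino link, sat well higher. Compound 4 keeps the sulfonyl but gains the amino link, so a modest rise in this assay is expected, short of the full gap to compound 2, with a 2.4-fold higher number from compound 3 to compound 4 (0.38 log units; beyond the scatter). Compound 4 is therefore estimated at 1200 nM, with a range of 400 nM to 4000 nM.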

Compound 4, half-maximal inhibitory concentration: 5000 nM
Beside the measured number, compound 4's estimate is 4.2-fold (0.62 log units) below it, and the stated range ends below it.
By their numbers in this assay, from the lowest: compounds 1 and 3 (each within the scatter of the next); then compounds 2 and 4 (each within the scatter of the next).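

Within the sulfonyl series, the earlier aryl swap on the sulfonyl sulfur was flat, but in this assay the amino link is not tolerated in the same way: the numbers show (a 10-fold higher number from compound 3 to compound 4 (1.00 log units; beyond the scatter)) and (a 13-fold higher number from compound 1 to compound 4 (1.10 log units; beyond the scatter)). With the 4-fluorophenyl end held, sulfamoyl and carbamoyl give (no change at the digits printed from compound 2 to compound 4 (within the scatter)), so among these four compounds the sulfonyl does not by itself keep the number low; only compound 1 and compound 3, with aryl directly on the sulfonyl sulfur, do, and no compound goes against this. No evidence is available that explains the rise.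

Still open, going by these compounds, is whether the rise follows the amino link itself or the hydrogen it carries. A methyl on the sulfamoyl nitrogen, or a methylene in place of that nitrogen, would separate the two.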